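The source may report more compounds than this note shows. Statements on the series, on what has been measured and on what is new or still open speak of the compounds shown alone.

Measured compounds:
compound 1 `CCN(CC)C(=O)Nc1ncc(C(Oc2ccc3cc(Br)ccc3c2)c2ccc(Cl)cc2)s1`: "not toxic" (no number reported)
compound 2 `O=C(Nc1ncc(C(Oc2ccc3cc(Br)ccc3c2)c2ccc(Cl)cc2)s1)c1ccc(F)cc1Br`: > 50000 nM

In an ADME assay on HepG2 2.2.15 cells (Homo sapiens) for cytotoxicity (on this read-out lower numbers stand for higher toxicity in this test and higher numbers for lower toxicity in this test), compound 2 gives > 50000 nM, which is a limit of the assay and not a number; it stands at the limit of > 50000 nM in this assay, at which 1 of the 2 values shown sits. Compound 1 gives "not toxic" (no number reported) in this assay, again without a number. Compound 3 `O=C(Nc1ncc(C(Oc2ccc3cc(Br)ccc3c2)c2ccc(Cl)cc2)s1)c1ccc(Cl)nc1` differs from compound 2 by 6-chloropyridin-3-yl in place of 2-bromo-4-fluorophenyl on a carbonyl carbon. Within the data shown here, no measured pair of this kind is available. The step is expected to be a number no higher from compound 2 to compound 3 (the limit leaves the size open), that is, nothing beyond the scatter, since compound 2 already sits at the limit. Compound 3 is estimated at 50000 nM, with a range from 20000 nM to 100000 nM.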

Compound 3, half-maximal cytotoxic concentration: "not toxic" (no number reported)
Compound 3 has no reported number here; the estimate stays without a comparison.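

In this assay compound 3 gives "not toxic" (no number reported), so no step can be read from compound 2 to compound 3. The compounds shown leave open how their cytotoxic concentrations compare, since none of them carries a single number.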